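Methoxyphenyl in place of dichlorophenyl on the carbonyl carbon

The source may report more compounds than this note shows. Statements on the series, on what has been measured and on what is new or still open speak of the compounds shown alone.

Compound 1 `COc1ccc(-c2cc(/C=C/C(=O)c3ccc(N)cc3)[nH]n2)cc1` and compound 2 `COc1cc(-c2cc(/C=C/C(=O)c3ccc(Cl)c(Cl)c3)[nH]n2)cc(OC)c1OC` were both tested in one read-out. In a functional assay on SK-OV-3 cells (Homo sapiens) for cytotoxicity, read by sulforhodamine B assay, with a stated time of 48 h, tested at 100 uM (on this read-out lower numbers stand for a stronger effect and higher numbers for a weaker effect at the one concentration tested), compound 1 gives -68%, and compound 2 gives -70%. Compound 2 stands at the lowest of the two numbers, yet its gap to compound 1 lies within the scatter. Compound 3 `COc1ccc(C(=O)/C=C/c2cc(-c3cc(OC)c(OC)c(OC)c3)n[nH]2)cc1` differs from compound 2 by 4-methoxyphenyl in place of 3,4-dichlorophenyl on a carbonyl carbon. Going by the values given here, no measured pair shows this change, so no step beyond the scatter is expected. Compound 3 is therefore expected to give -65% in this assay, within -85% to -45%. The estimated step of a number 5 percentage points higher from compound 2 to compound 3 (within the scatter) is expected to stay within the scatter.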

Compound 3, a percentage reported as activity, at one concentration (the size of the read-out at that concentration, not a potency): -41%
Compound 3: the middle estimate sits 24 percentage points below what was measured; the whole stated range lies below it.
By their numbers in this assay, from the lowest: compounds 2 and 1 (each within the scatter of the next); then compound 3.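

In this assay, 4-methoxyphenyl in place of 3,4-dichlorophenyl on the carbonyl carbon gives a number 29 percentage points higher from compound 2 to compound 3 (beyond the scatter), a weaker effect at the one concentration tested. Going by these compounds alone, this shows that the group on this carbonyl carbon matters to the read-out, which the earlier compounds could not show, since they differ in more than one place. Nothing available explains this step.

As far as these compounds go, the swap removes both chlorines and adds the methoxy group at once, so their separate contributions remain open. From the compounds shown here alone, it also remains open where a 4-chlorophenyl or an unsubstituted phenyl on this carbon would fall.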